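The source may hold more compounds than are shown below. What is called first, only, known or untested is meant among the compounds shown, and "the series" means these compounds.

Measured in a physicochemical assay for solubility, measured as kinetic solubility; a higher number here means a more soluble compound, a lower number a less soluble compound:
- Compound 1 `CCC/N=C1\S/C(=C\c2ccc(O)c(Cl)c2)C(=O)N1C1CCN(C)C(=O)C1`: > 250000 nM
- Compound 2 `CCC/N=C1\S/C(=C\c2ccc(O)c(Cl)c2)C(=O)N1c1ccccc1O`: 220000 nM

Compound 1 stands at > 250000 nM, which is a limit of the assay and not a number. Among the measured compounds shown here, compound 2, at 220000 nM, holds the only actual number so far. Compound 3 `CCC/N=C1\S/C(=C\c2ccc(O)c(Cl)c2)C(=O)N1c1ccccc1OC` differs from compound 2 in one place: methyl in place of hydrogen on an oxygen on an aromatic ring, turning hydroxy into methoxy. For the measured compounds named here, the single measured step, an at least 1.1-fold lower number from compound 1 to compound 2 (0.05 log units; that floor lies within the scatter), involves a different change and offers only a weak guide. No change beyond the scatter is therefore expected in this assay, and the estimated step is a 1.3-fold lower number from compound 2 to compound 3 (0.11 log units; within the scatter). For compound 3 the expected value is 170000 nM, with an estimated range of 60000 nM to 250000 nM.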

Compound 3, solubility: 79000 nM
Estimate against measurement, compound 3: 2.2-fold (0.33 log units) above; measured number inside the range.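

In this assay, among the compounds shown here, one added methyl on this oxygen on an aromatic ring moves the read-out beyond the scatter, with a 2.8-fold lower number from compound 2 to compound 3 (0.44 log units; beyond the scatter), something no earlier pair showed for this position. Replacing 1-methyl-2-oxopiperidin-4-yl with 2-methoxyphenyl also gives a step beyond the scatter, with an at least 3.1-fold lower number from compound 1 to compound 3 (0.50 log units; beyond the scatter). Compound 1 stands at a limit of the assay, not at a number, so that step is only a floor: the limit of > 250000 nM in this assay, at which 1 of the 3 values shown sits.

Going by these compounds, whether a longer chain on this oxygen, as in ethoxy, would go further remains open. So does what an amine in place of the hydroxy would give.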